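Moving the trifluoromethoxy group around the phenyl ring

This account rests on a few compounds, and the source may have more. Where it says the series, first, only, none or still open, it means among the compounds named here.

Measured in an in vivo ADME assay on the whole organism for pharmacokinetics, with Rattus norvegicus as the target, at a dose of 4 mg/kg; on this read-out higher numbers stand for higher oral bioavailability and lower numbers for lower oral bioavailability:
Compound 1 `CCCc1cc(N[C@@H](CC(C)C)C(=O)NCCCOCC)nc(-n2cnc(-c3ccc(OC(F)(F)F)cc3)c2)n1`: 33%
Compound 2 `CCCc1cc(N[C@@H](CC(C)C)C(=O)NCCCOCC)nc(-n2cnc(-c3cccc(OC(F)(F)F)c3)c2)n1`: 7%

On this assay, compound 2 stands lowest of the two measured compounds at 7%, and compound 1 gives 33%. Compound 3 `CCCc1cc(N[C@@H](CC(C)C)C(=O)NCCCOCC)nc(-n2cnc(-c3ccccc3OC(F)(F)F)c2)n1` differs from compound 2 at one place: 2-(trifluoromethoxy)phenyl in place of 3-(trifluoromethoxy)phenyl on an aromatic carbon. In words, 2-(trifluoromethoxy)phenyl comes in place of 3-(trifluoromethoxy)phenyl on an aromatic carbon. Among the measured compounds shown here, the one measured step that bears on this is the swap of the 4-(trifluoromethoxy)phenyl group for the 3-(trifluoromethoxy)phenyl group, a number 26 percentage points lower from compound 1 to compound 2 (beyond the scatter). That modest step shows that the placement of this group can count here, but it gives no direction for the new placement. With compound 2 already at 7%, a small rise is expected, possibly none beyond the scatter. The expected change is a number 7 percentage points higher from compound 2 to compound 3 (within the scatter). For compound 3 the estimate is 14%, with an expected range of 3% to 32%.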

Compound 3, oral bioavailability: 5%
Compound 3: the middle estimate sits 9 percentage points above what was measured; the measured number falls inside the stated range.
By their numbers in this assay, from the lowest: compounds 3 and 2 (each within the scatter of the next); then compound 1.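

In this assay, moving the trifluoromethoxy group to the 2-(trifluoromethoxy)phenyl arrangement gives a number 2 percentage points lower from compound 2 to compound 3 (within the scatter) and so does not separate this group from the 3-(trifluoromethoxy)phenyl group. Against the 4-(trifluoromethoxy)phenyl group the same change gives a number 28 percentage points lower from compound 1 to compound 3 (beyond the scatter) and thus shows that, of the three arrangements on this phenyl ring, only the one in compound 1 stands apart, with the highest oral bioavailability. Nothing shown here gives a measured reason for this difference.

The compounds shown leave open whether the higher number of compound 1 depends on the trifluoromethoxy group itself or would also appear with a 4-methoxyphenyl, a 4-chlorophenyl or a plain phenyl group. They also leave open how a change elsewhere on the molecule, such as a shorter chain in place of the propyl group, would act alongside this one.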